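Swapping a Methylamino Urea for a Morpholine Amide

This account rests on a few compounds, and the source may have more. Where it says the series, first, only, none or still open, it means among the compounds named here.

Of the compounds shown here, two sharing one core have been measured in an assay on L1.2 cells for binding affinity to C-C chemokine receptor type 8 (Homo sapiens); a higher number here means a weaker inhibitor, a lower number a stronger inhibitor. Compound 1 `Cc1ccccc1C(=O)Nc1ccc(S(=O)(=O)NC2CCN(C(N)=O)CC2)c2ccccc12` carries a plain urea, and in this assay compound 1 gives 243 nM. Compound 2 `CNC(=O)N1CCC(NS(=O)(=O)c2ccc(NC(=O)c3ccccc3C)c3ccccc23)CC1` differs only by a methyl on the urea nitrogen, and in this assay compound 2 gives 0.7 nM. The step of a 350-fold lower number from compound 1 to compound 2 (2.54 log units; beyond the scatter) is the only one measured, and it leaves compound 2 standing at the lowest number of the two. Compound 3 `Cc1ccccc1C(=O)Nc1ccc(S(=O)(=O)NC2CCN(C(=O)N3CCOCC3)CC2)c2ccccc12` is the next variation: morpholin-4-yl in place of methylamino on a carbonyl carbon. Among the measured compounds shown here, the single measured step bears on this only loosely, since it shows that a methyl on that nitrogen went with a large gain, but it says nothing about removing the remaining hydrogen on the nitrogen or about a six-membered ring at that carbonyl. A modest rise in the number is therefore expected, a 4.3-fold higher number from compound 2 to compound 3 (0.63 log units; beyond the scatter), though a step within the scatter would not surprise. Compound 3 is estimated at 3 nM in this assay, with a range from 0.5 nM to 30 nM.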

Compound 3, inhibition constant: 6.3 nM
Compound 3: the middle estimate sits 2.1-fold (0.32 log units) below what was measured; measured number inside the range.
By their numbers in this assay, from the lowest: compound 2; then compound 3; then compound 1.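

The carbonyl carbon on the amide-type ring nitrogen accepts much more than the small methylamino group: with morpholin-4-yl, which has 6 heavy atoms, a six-membered non-aromatic ring and 0 hydrogen-bond donors, this assay shows a 9.0-fold higher number from compound 2 to compound 3 (0.95 log units; beyond the scatter) and the compound keeps most of its strength. The plain amino group remains far behind, with a 39-fold lower number from compound 1 to compound 3 (1.59 log units; beyond the scatter), so both substituted groups shown give much lower numbers than amino, with no compound here going against that, while methylamino still gives the lowest number of the three. No measurement shown explains why these groups rank in this order.

Going by these compounds, two questions stay open, since morpholin-4-yl differs from methylamino in several ways at once. Dimethylamino would show what removing the remaining hydrogen on that nitrogen does without adding a ring, and piperidin-1-yl, which has a carbon where morpholin-4-yl has its ring oxygen, would show whether that oxygen matters to the number in this assay at this carbonyl.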